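Adding a Nitro Group to Compound 1: Cytotoxicity Outlook

The compounds below may be only part of what the source reports. "The series", "measured", "known", "first", "only" and "open" are said of these compounds alone.

Measured compounds:
Compound 1 `COc1c(N2CCN(C(c3ccccc3)c3ccc(Cl)cc3)CC2)c(F)cc2c(=O)c(C(=O)O)cn(C3CC3)c12` — compound 1 gives "not determined" (no result reported) in an ADME assay on Vero cells (Chlorocebus sabaeus) for cytotoxicity, read by MTT assay, with a stated time of 72 h; a higher number here means a weaker inhibitor, a lower number a stronger inhibitor.
Compound 2 `COc1c(N2CC(C)OC(C)C2)c(F)cc2c(=O)c(C(=O)O)cn(C3CC3)c12` — compound 2 gives 160000 nM in this assay.
Compound 3 `COc1c(N2COCC2(C)C)c(F)cc2c(=O)c(C(=O)O)cn(C3CC3)c12` — compound 3 gives 166000 nM in this assay.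

Compound 1 therefore has no number of its own in this assay, and it cannot be placed relative to compound 2 or compound 3. Compound 4 `COc1c(N2CCN(C(c3ccccc3)c3ccc(Cl)cc3)CC2)c(F)c([N+](=O)[O-])c2c(=O)c(C(=O)O)cn(C3CC3)c12` arises from compound 1 by a single change: nitro in place of hydrogen on an aromatic carbon. Going by the values given here, the only measured step, a 1.0-fold higher number from compound 2 to compound 3 (0.02 log units; within the scatter), concerns a different change at a different site and lies within the scatter; no measured step bears on the introduction of a nitro group. What the data do show is that both compound 2 and compound 3 are weak inhibitors here. On that basis alone, compound 4 is estimated to give about 100000 nM in this assay, with an expected range from 20000 nM to 250000 nM, and this estimate carries wide uncertainty.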

Compound 4, half-maximal inhibitory concentration: 103000 nM
Compound 4: the middle estimate sits 1.0-fold (0.01 log units) below what was measured; the measured number falls inside the stated range.
By their numbers in this assay, from the lowest: compounds 4, 2 and 3 (each within the scatter of the next).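

Going by these compounds alone, compound 1 has no single number in this assay, so no step to compound 4 can be read. The compounds shown leave open how nitro in place of hydrogen shifts this number. No evidence shown bears on the result.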